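Trimming the N-substituent of a trimethoxybenzyl purine analogue

The compounds below may be only part of what the source reports. "The series", "measured", "known", "first", "only" and "open" are said of these compounds alone.

This account follows a pair of purine-like compounds tested in a functional assay on MCF7 cells (Homo sapiens) for antiproliferative activity; a higher number here means a weaker inhibitor, a lower number a stronger inhibitor. Compound 1, `CCCCn1c(Cc2c(Br)c(OC)c(OC)c(OC)c2Br)nc2c(N)ncnc21`, is the stronger of the two measured entries; in this assay compound 1 gives 30200 nM. Compound 2, `COc1cc(Cc2nc3c(N)ncnc3n2CC2CCCO2)cc(OC)c1OC`, stands at the higher of the two numbers; in this assay compound 2 gives 91200 nM, a gap to compound 1 that lies beyond the usual scatter. Compound 1 and compound 2 differ in more than one place, so no single change can be read from their two values.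

Compound 3, `CCn1c(Cc2cc(OC)c(OC)c(OC)c2)nc2c(N)ncnc21`, has not yet been measured. It departs from compound 2 by one change, (methyl in place of oxolan-2-yl on a saturated chain carbon bound to an aromatic nitrogen). Within the data shown here, no step between measured compounds isolates this kind of change, so the expectation rests on the two values alone. A small step toward a lower number, or none beyond the scatter, is expected from compound 2 to compound 3, estimated as a 1.5-fold lower number from compound 2 to compound 3 (0.18 log units; within the scatter). Compound 3 is therefore expected to give about 60000 nM in this assay, within a range from 15000 nM to 200000 nM.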

Compound 3, half-maximal inhibitory concentration: 79400 nM
Compound 3: the middle estimate sits 1.3-fold (0.12 log units) below what was measured; the measured number falls inside the stated range.
By their numbers in this assay, from the lowest: compound 1; then compounds 3 and 2 (each within the scatter of the next).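

In this assay, among these compounds, the change from (oxolan-2-yl)methyl to ethyl gives the first step that can be read at this place, on a saturated chain carbon bound to an aromatic nitrogen (a 1.1-fold lower number from compound 2 to compound 3 (0.06 log units; within the scatter)). The oxolan-2-yl group, with its five-membered non-aromatic ring and its hydrogen-bond acceptor, gives way to a single methyl carrying neither, yet the two numbers stay within the scatter of each other, so for this pair the ring and its oxygen leave no readable mark on the result. Nothing available explains why the exchange leaves so little trace.

Compound 1 differs from compound 2 and compound 3 in more than one place, with a butyl chain on the aromatic nitrogen and bromine on the trimethoxybenzyl part, so its gap to either of them cannot be read as a step and neither feature can be credited on its own. Also open, from the compounds shown here alone, is whether this place stays as indifferent with a different kind of group, such as an amine or a carboxylic acid at the end of the chain, since the ethyl and (oxolan-2-yl)methyl pair alone cannot settle it.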